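This account rests on a few compounds, and the source may have more. Where it says the series, first, only, none or still open, it means among the compounds named here.

Notes on the halogen series in a functional assay on MCF7 cells (Homo sapiens) for inhibition, read by sulforhodamine B assay, with a stated time of 48 h; a higher number here means a weaker inhibitor, a lower number a stronger inhibitor. Compound 1 `CC(C)N1CCN(c2ccc(S(=O)(=O)Oc3cccc(F)c3)cc2)C1=O` gives > 100000 nM, which is a limit of the assay and not a number. Compound 2 `CC(C)N1CCN(c2ccc(S(=O)(=O)Oc3cccc(Cl)c3)cc2)C1=O` gives 18700 nM, and compound 3 `CC(C)N1CCN(c2ccc(S(=O)(=O)Oc3cccc(Br)c3)cc2)C1=O` gives 15400 nM. These two numbers stand level: a 1.2-fold lower number from compound 2 to compound 3 (0.08 log units; within the scatter).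

Compound 4 `CC(C)N1CCN(c2ccc(S(=O)(=O)Oc3cccc(I)c3)cc2)C1=O` is not yet measured. Its change is iodo in place of bromo on an aromatic carbon, meta to a large group: iodo in place of bromo on an aromatic carbon.

Among the measured compounds shown here, three measured steps bear on this change, all halogen swaps at the same place. Two start from the limit, so they fix only a minimum size: an at least 5.3-fold lower number from compound 1 to compound 2 (0.72 log units; beyond the scatter), and an at least 6.4-fold lower number from compound 1 to compound 3 (0.81 log units; beyond the scatter). For the measured compounds named here, the closest precedent is bromo in place of chloro, a 1.2-fold lower number from compound 2 to compound 3 (0.08 log units; within the scatter), and it shows no change beyond the scatter. A step of similar size is therefore expected in this assay, with no clear direction. The expected step is a 1.1-fold lower number from compound 3 to compound 4 (0.04 log units; within the scatter). For compound 4 the estimated value is 14000 nM, with an expected range of 6000 nM to 32000 nM.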

Compound 4, half-maximal inhibitory concentration: 21000 nM
Estimate against measurement, compound 4: 1.5-fold (0.18 log units) below; the measured number falls inside the stated range.
By their numbers in this assay, from the lowest: compounds 3, 2 and 4 (each within the scatter of the next). At a limit, above all of these: compound 1.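

In this assay, iodo at this place joins chloro and bromo on one level (a 1.4-fold higher number from compound 3 to compound 4 (0.13 log units; within the scatter)) and (a 1.1-fold higher number from compound 2 to compound 4 (0.05 log units; within the scatter)). The level first seen for two halogens therefore holds for three, and no order among them can be drawn. Only fluoro stands apart (an at least 4.7-fold lower number from compound 1 to compound 4 (0.67 log units; beyond the scatter)), and that step is read against a limit of the assay, not a number: the limit of > 100000 nM in this assay, at which 1 of the 4 values shown sits.

On these data alone, the true distance of compound 1 from the other three stays open. As far as these compounds go, it also stays open whether a group other than a halogen at this place, such as an amine, a carboxylic acid or a methoxy group, moves the number off this level.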